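Changing the heteroaryl group on a shared sulfonamide

A few compounds are considered here, and "the series" means these few. Any claim that something is new, unique, unknown or untested is made for them only; others in the source may bear on it.

Of the compounds shown here, three built on one shared core have been measured. In a functional assay on T47D cells (Homo sapiens) for cytotoxicity, read by sulforhodamine B assay, with a stated time of 48 h (on this read-out higher numbers stand for weaker inhibition and lower numbers for stronger inhibition), compound 1 `N=C(N)NS(=O)(=O)c1ccc(N/C=C\C(=O)c2cc3ccccc3oc2=O)cc1` gives 87600 nM. Compound 2 `Cc1noc(NS(=O)(=O)c2ccc(N/C=C\C(=O)c3cc4ccccc4oc3=O)cc2)c1C`, which carries a five-membered ring on the sulfonamide nitrogen, gives 68400 nM in this assay, and the step of a 1.3-fold lower number from compound 1 to compound 2 (0.11 log units; within the scatter). Compound 3 `O=C(/C=C\Nc1ccc(S(=O)(=O)Nc2ncccn2)cc1)c1cc2ccccc2oc1=O` gives 75200 nM; the steps of a 1.2-fold lower number from compound 1 to compound 3 (0.07 log units; within the scatter) and a 1.1-fold higher number from compound 2 to compound 3 (0.04 log units; within the scatter). Compound 3 thus sits among three numbers that cannot be told apart, and none of the three can be called stronger or weaker than another.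

Compound 4 `Cc1cc(NS(=O)(=O)c2ccc(N/C=C\C(=O)c3cc4ccccc4oc3=O)cc2)nc(C)n1` is the next member. The change from compound 3 is 2,6-dimethylpyrimidin-4-yl in place of pyrimidin-2-yl on a sulfonamide nitrogen. Going by the values given here, no measured step covers exactly this exchange, but every exchange so far on the same sulfonamide nitrogen, from an open-chain group to a five-membered ring to a six-membered ring, stayed within the scatter. The expectation is therefore that this assay will show no step beyond the scatter, and the step of a 1.0-fold lower number from compound 3 to compound 4 (0.00 log units; within the scatter) is estimated accordingly. Compound 4 is expected to give about 75000 nM in this assay, within a range from 35000 nM to 160000 nM.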

Compound 4, half-maximal inhibitory concentration: 100000 nM
For compound 4 the middle estimate is 1.3-fold (0.12 log units) below the measured one; measured number inside the range.
By their numbers in this assay, from the lowest: compounds 2, 3, 1 and 4 (each within the scatter of the next).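

In this assay, putting 2,6-dimethylpyrimidin-4-yl in place of pyrimidin-2-yl on the sulfonamide nitrogen gives a step (a 1.3-fold higher number from compound 3 to compound 4 (0.12 log units; within the scatter)), so this exchange between two six-membered aromatic rings, with a larger group entering, cannot be told apart from repeated measurement. Comparing the same group with the five-membered ring of compound 2 (a 1.5-fold higher number from compound 2 to compound 4 (0.16 log units; within the scatter)) and with the open-chain group of compound 1 (a 1.1-fold higher number from compound 1 to compound 4 (0.06 log units; within the scatter)) gives the same picture, which means all four groups on this nitrogen now sit together, with no pair separated by more than the scatter. Nothing measured here offers an explanation for this flat picture.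

From the compounds shown here alone, whether any group on this nitrogen can move the number beyond the scatter remains open, and a plain phenyl ring, a longer alkyl chain or simply a hydrogen there would each test this in a different way. The rest of the shared core is identical in all four compounds, so these results also leave open what a change elsewhere in the molecule, such as an added amine or carboxylic acid, would do.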